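Oxindole ylidene series: bromo substitution on the fused ring

The source may report more compounds than this note shows. Statements on the series, on what has been measured and on what is new or still open speak of the compounds shown alone.

Measured compounds
compound 1: `O=C1NC(=O)/C(=C2/C(=O)Nc3ccccc32)N1`, 95500 nM
compound 2: `O=C1NC(=S)N/C1=C1\C(=O)Nc2ccccc21`, 75500 nM

Two compounds have been run in a functional assay on PC-3 cells (Homo sapiens) for antiproliferative activity, read by MTT assay, with a stated time of 72 h; on this read-out higher numbers stand for weaker inhibition and lower numbers for stronger inhibition. Compound 1 gives 95500 nM and compound 2 gives 75500 nM. Compound 2 holds the lowest of the two numbers, but its nearest neighbour, compound 1, sits within the usual scatter, so no order between them can be claimed. Within the data shown here, no pair of measured compounds differing in one place is available, so no measured step guides the next change.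

Compound 3 `O=C1NC(=S)N/C1=C1\C(=O)Nc2c(Br)cccc21` is the next to be measured in this assay. Relative to compound 2 it shows (bromo in place of hydrogen on an aromatic carbon). With no measured step of this kind in hand, the expected step of a 1.5-fold lower number from compound 2 to compound 3 (0.18 log units; within the scatter) is at most a modest lowering of the number, and possibly nothing beyond the scatter. Compound 3 is accordingly estimated at 50000 nM, with a range of 15000 nM to 160000 nM.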

Compound 3, half-maximal inhibitory concentration: 22800 nM
Beside the measured number, compound 3's estimate is 2.2-fold (0.34 log units) above it; measured number inside the range.
By their numbers in this assay, from the lowest: compound 3; then compounds 2 and 1 (each within the scatter of the next).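

In this assay, among these compounds, the change to bromo gives a 3.3-fold lower number from compound 2 to compound 3 (0.52 log units; beyond the scatter) and so supplies the first step that lies beyond the scatter. A single bromine atom on this aromatic carbon, ortho to a fused ring and meta to a fused ring, is enough to lower the number, so this position responds to substitution, at least for this one group. No measurement at hand accounts for the step.

From the compounds shown here alone, whether the lowering belongs to bromo itself or would also follow from other groups on this carbon stays open, and chloro, methyl, methoxy or an amine here would help to separate those readings. Also open, going by these compounds, are whether the other aromatic carbons of this ring respond in the same way and whether bromo has a similar effect on the core of compound 1.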